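Acetylpiperidinyl in Place of Cyclopropyl on the Core Nitrogen

A few compounds are considered here, and "the series" means these few. Any claim that something is new, unique, unknown or untested is made for them only; others in the source may bear on it.

Compound 2 `CC(C)c1onc(-c2c(Cl)cccc2Cl)c1COc1ccc(-c2nc3ccc(C(=O)O)cc3n2C2CC2)cc1` was tested in an assay on HEK-293T cells for antagonist activity at vitamin D3 receptor (Homo sapiens), read by a luciferase reporter, with a stated time of 24 h (on this read-out lower numbers stand for stronger inhibition and higher numbers for weaker inhibition), where compound 2 gives 3200 nM. Among the two results shown for this series, this is the only actual number; the other result is a limit. Compound 1 `CCC(CC)n1c(-c2ccc(OCc3c(-c4c(Cl)cccc4Cl)noc3C(C)C)cc2F)nc2ccc(C(=O)O)cc21`, a close relative sharing the same core, reaches only the limit of > 10000 nM in this assay, which is the limit of > 10000 nM in this assay, at which 1 of the 2 values shown sits. Among the measured compounds shown here, no step between these two measured compounds is worked out here, so their values show only that compound 1 remains beyond the limit while compound 2 returns a number.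

Compound 3 `CC(=O)N1CCC(n2c(-c3ccc(OCc4c(-c5c(Cl)cccc5Cl)noc4C(C)C)cc3)nc3ccc(C(=O)O)cc32)CC1` has not yet been measured. It differs from compound 2 in a single place: 1-acetylpiperidin-4-yl in place of cyclopropyl on an aromatic nitrogen.

For the measured compounds named here, no measured step in this assay shows what a change at this ring nitrogen does, so the direction of the step remains open. Compound 3 is expected to give about 3000 nM, with a range from 800 nM to 15000 nM. The expected step of a 1.1-fold lower number from compound 2 to compound 3 (0.03 log units; within the scatter) is therefore estimated as none beyond the usual scatter, with a real chance that only a limit is reported.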

Compound 3, half-maximal inhibitory concentration: > 10000 nM
Compound 3: only a limit was reported; the forecaster's own chance of this, stated with the estimate: 35%; middle value at least 3.3-fold (0.52 log units) away from the limit.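

The nitrogen of the shared core proves sensitive to what it carries: 1-acetylpiperidin-4-yl in place of cyclopropyl gives an at least 3.1-fold higher number from compound 2 to compound 3 (0.49 log units; beyond the scatter) in this assay. Compound 3 gives > 10000 nM, which is a limit of the assay and not a number, so this step has a lower bound but no known size. Among the compounds shown, the cyclopropyl of compound 2 is now the only group on this nitrogen that returns a number, and most of the series rests at the limit: the limit of > 10000 nM in this assay, at which 2 of the 3 values shown sit.

The compounds shown leave open whether the change in read-out follows the acetyl group or the six-membered ring itself, and a cyclohexyl or an unsubstituted piperidin-4-yl on this nitrogen would separate the two. Also open, from the compounds shown here alone, is whether any group other than cyclopropyl on this nitrogen, such as a cyclobutyl or a short chain like ethyl, would keep a measurable number or give a lower one than that of compound 2.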